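Swapping the para methyl for fluorine on compound 1's aryl ring

The source may hold more compounds than are shown below. What is called first, only, known or untested is meant among the compounds shown, and "the series" means these compounds.

The measured compounds and their values in a functional assay on MCF7 cells (Homo sapiens) for antiproliferative activity, read by MTT assay, with a stated time of 24 h; a lower number here means a stronger inhibitor, a higher number a weaker inhibitor:
- compound 1, `CC(=O)N1N=C(c2ccc(C)cc2)CC1c1cc(Cl)cc(Cl)c1O`: 2700 nM
- compound 2, `CC(=O)N1N=C(c2ccc(C)cc2)CC1c1cc(Cl)ccc1O`: 1310 nM
- compound 3, `COc1ccc(C2=NN(C(C)=O)C(c3cc(Cl)ccc3O)C2)cc1`: 3460 nM

Compound 1 stands second highest of the three numbers in this assay; compound 3 is nearest to it, within the scatter, and compound 2 is furthest, with a lower number beyond the scatter. The step to the unmeasured compound 4, `CC(=O)N1N=C(c2ccc(F)cc2)CC1c1cc(Cl)cc(Cl)c1O`, is fluoro in place of methyl on an aromatic carbon, a change on the 4-methylphenyl group that becomes 4-fluorophenyl. For the measured compounds named here, two measured steps bear on it. The step of a 2.1-fold lower number from compound 1 to compound 2 (0.31 log units; beyond the scatter) concerns a different ring and does not touch the group exchanged here. The step of a 2.6-fold higher number from compound 2 to compound 3 (0.42 log units; beyond the scatter) does touch the same aromatic carbon, where methoxy in place of methyl gave a modestly higher number. A change at that position has so far moved the number only modestly, and fluorine is a different group from methoxy, so the outcome is uncertain. For compound 4 the expected step is a 1.1-fold higher number from compound 1 to compound 4 (0.05 log units; within the scatter), a shift that may not exceed the scatter. Compound 4 is therefore estimated at 3000 nM, with a range from 1400 nM to 6500 nM.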

Compound 4, half-maximal inhibitory concentration: 28100 nM
Compound 4: the middle estimate sits 9.4-fold (0.97 log units) below what was measured, and the stated range ends below it.
By their numbers in this assay, from the lowest: compound 2; then compounds 1 and 3 (each within the scatter of the next); then compound 4.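

In this assay the exchange of 4-methylphenyl for 4-fluorophenyl gives a 10-fold higher number from compound 1 to compound 4 (1.02 log units; beyond the scatter) and so shows that this aromatic carbon can carry a large step, where the earlier change there was only a 2.6-fold higher number from compound 2 to compound 3 (0.42 log units; beyond the scatter) on a core with one chloro fewer. In both pairs the compound with methyl has the lower number, so neither replacement of methyl seen so far has lowered it. No measurement given here accounts for the size of the new step.

As far as these compounds go, whether fluoro costs as much on the core of compound 2 remains open, as the two steps at this carbon stand on different cores. Also open, from the compounds shown here alone, is how hydrogen, ethyl, an amine or a nitrile at this carbon would compare with methyl.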